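A few compounds are considered here, and "the series" means these few. Any claim that something is new, unique, unknown or untested is made for them only; others in the source may bear on it.

Measured in an ADME assay on RAW264.7 cells (Mus musculus) for cytotoxicity, read by MTT assay, with a stated time of 24 h; on this read-out higher numbers stand for lower toxicity in this test and lower numbers for higher toxicity in this test:

Compound 1, `O=c1oc2ccc(Br)cc2c(=O)n1-c1ccc(Br)cc1F`, gives 7200 nM.
Compound 2, `O=C(Nc1ccc(Br)cc1F)c1cc(F)ccc1O`, gives 7900 nM.
Compound 3, `O=c1oc2ccc(Br)cc2c(=O)n1-c1ccc(Cl)cc1F`, gives 7500 nM.

Compound 3 differs from compound 1 by chloro in place of bromo on an aromatic carbon, and in this assay this gives a 1.0-fold higher number from compound 1 to compound 3 (0.02 log units; within the scatter). The difference between the core of compound 1 and the core of compound 2 is not broken down here; the three numbers all lie within the usual scatter of each other.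

Compound 4, `O=C(Nc1ccc(Cl)cc1F)c1cc(F)ccc1O`, is not yet measured. It differs from compound 2 by chloro in place of bromo on an aromatic carbon, the same change as from compound 1 to compound 3, at a place described in identical words. Because a 1.0-fold higher number from compound 1 to compound 3 (0.02 log units; within the scatter) was within the scatter, the step is expected to be a 1.0-fold higher number from compound 2 to compound 4 (0.01 log units; within the scatter). On that basis compound 4 is estimated at 8000 nM in this assay, expected between 4000 nM and 16000 nM.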

Compound 4, half-maximal cytotoxic concentration: 7700 nM
For compound 4 the middle estimate is 1.0-fold (0.02 log units) above the measured one; the range from low to high includes it.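

In this assay chloro in place of bromo on an aromatic carbon gives a 1.0-fold lower number from compound 2 to compound 4 (0.01 log units; within the scatter) and so shows no readable effect on the core of compound 2. Set beside the earlier step, the change carries across the two cores without a visible difference: the same change on two cores in this assay, a 1.0-fold higher number (0.02 log units; within the scatter) from compound 1 to compound 3 and a 1.0-fold lower number (0.01 log units; within the scatter) from compound 2 to compound 4, 1.1-fold (0.03 log units) apart, within the scatter of two such steps. This supports treating the swap as silent on these two cores in this one test, but it does not show that it would stay silent on a further core or in any other test.

Open, going by these compounds, is how this place responds to groups other than the two halogens, such as an amine, a methoxy group or a carboxylic acid. Also open, on these data alone, is whether a trifluoromethyl or a nitrile in place of the fluoro group would move the number.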